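Benzyl carbamate as the next step in the series

This account rests on a few compounds, and the source may have more. Where it says the series, first, only, none or still open, it means among the compounds named here.

The three measured compounds share one core and differ only in the group on the carbamate nitrogen. Compound 1 `C/C(=C\COC(=O)Nc1ccccc1)C1=CC(=O)C(C)(C)O1` carries phenyl there. In a functional assay on L1210 cells (Mus musculus) for inhibition (on this read-out higher numbers stand for weaker inhibition and lower numbers for stronger inhibition), compound 1 gives > 200 ug/mL, which is a limit of the assay and not a number. Going by the values given here, the single value standing at the limit of > 200 ug/mL in this assay, at which 1 of the 3 values shown sits, is that of compound 1. Compound 2 `C/C(=C\COC(=O)NC(C)C)C1=CC(=O)C(C)(C)O1` carries isopropyl and in this assay gives 4.9 ug/mL. Compound 3 `C=CCNC(=O)OC/C=C(\C)C1=CC(=O)C(C)(C)O1` carries allyl and in this assay gives 6.2 ug/mL, the higher of the two numbers, though with compound 2 inside the scatter: a 1.3-fold higher number from compound 2 to compound 3 (0.10 log units; within the scatter). The large steps are an at least 40-fold lower number from compound 1 to compound 2 (1.61 log units; beyond the scatter) and an at least 32-fold lower number from compound 1 to compound 3 (1.50 log units; beyond the scatter), both away from the aromatic group bound directly to the nitrogen.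

Compound 4 `C/C(=C\COC(=O)NCc1ccccc1)C1=CC(=O)C(C)(C)O1` differs from compound 3 by phenyl in place of vinyl on a saturated chain carbon bound to an amide-type nitrogen. The phenyl thus returns, but on the chain carbon rather than on the nitrogen itself, so the step from compound 1 to compound 3 bears on it only in part, and the step from compound 2 to compound 3 suggests that small changes of the chain itself matter little. A moderate rise is therefore expected, a 2.4-fold higher number from compound 3 to compound 4 (0.38 log units; beyond the scatter), well short of the limit seen for compound 1. Compound 4 is estimated at 15 ug/mL in this assay, within 4 ug/mL to 80 ug/mL.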

Compound 4, half-maximal inhibitory concentration: 4.7 ug/mL
Beside the measured number, compound 4's estimate is 3.2-fold (0.50 log units) above it; the measured number falls inside the stated range.
By their numbers in this assay, from the lowest: compounds 4, 2 and 3 (each within the scatter of the next). At a limit, above all of these: compound 1.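

Phenyl in place of vinyl on a saturated chain carbon bound to an amide-type nitrogen leaves the number in this assay within the scatter, a 1.3-fold lower number from compound 3 to compound 4 (0.12 log units; within the scatter), and benzyl in place of isopropyl does the same, a 1.0-fold lower number from compound 2 to compound 4 (0.02 log units; within the scatter), so the phenyl group as such does not bring back the result of compound 1 once a saturated chain carbon stands on the nitrogen. The contrast now rests on a single pair of groups on the same nitrogen, benzyl in place of phenyl, which makes a large step, an at least 42-fold lower number from compound 1 to compound 4 (1.62 log units; beyond the scatter). The value of compound 1 remains a limit of the assay: the limit of > 200 ug/mL in this assay, at which 1 of the 4 values shown sits.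

Still open, as far as these compounds go, is whether this tolerance holds for a longer chain between the nitrogen and the phenyl, such as phenethyl, or for a benzyl group bearing chlorine, methoxy or a carboxylic acid on its ring. Also open, from the compounds shown here alone, is whether the result of compound 1 belongs to phenyl alone or extends to other aromatic groups bound directly to the nitrogen, such as pyridyl or naphthyl.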